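Hydrazone variation on a shared triazole core: compound 3

The source may hold more compounds than are shown below. What is called first, only, known or untested is meant among the compounds shown, and "the series" means these compounds.

Measured compounds:
compound 1, `Brc1ccc(CSc2nnc(-c3ccncc3)n2-c2ccccc2)cc1`, 12600 nM
compound 2, `O=C(CSc1nnc(-c2ccncc2)n1-c1ccccc1)N/N=C/c1ccc(Cl)cc1`, 9930 nM

Both compounds were tested in a functional assay on MCF7 cells (Homo sapiens) for inhibition, read by MTT assay, with a stated time of 48 h; on this read-out higher numbers stand for weaker inhibition and lower numbers for stronger inhibition. Compound 2 gives 9930 nM, the lower of the two numbers, while compound 1 gives 12600 nM; the gap between them lies within the scatter, so the two cannot be told apart on these data.

Compound 3, `O=C(CSc1nnc(-c2ccncc2)n1-c1ccccc1)N/N=C/C=C/c1ccccc1`, keeps the core and the hydrazone of compound 2 and differs only in the aryl part: 2-phenylethenyl in place of 4-chlorophenyl on a carbon with a double bond to nitrogen. For the measured compounds named here, no pair of measured compounds shows what such a change does in this assay, so there is no step to lean on. Compound 3 is therefore expected to come out close to compound 2, with a step of a 1.1-fold lower number from compound 2 to compound 3 (0.04 log units; within the scatter) that stays within the scatter. On that basis compound 3 is estimated at 9000 nM, within a range from 3500 nM to 25000 nM.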

Compound 3, half-maximal inhibitory concentration: 11200 nM
For compound 3 the middle estimate is 1.2-fold (0.09 log units) below the measured one; the measured number falls inside the stated range.
By their numbers in this assay, from the lowest: compounds 2, 3 and 1 (each within the scatter of the next).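

The change of the aryl part gives, in this assay, a 1.1-fold higher number from compound 2 to compound 3 (0.05 log units; within the scatter), the first step read at this position. For the compounds shown here, the number therefore does not separate these two aryl parts, even though the swap removes the chlorine and adds a double bond outside aromatic rings; the single step cannot show what each of these contributes alone. Nothing available offers a reason for this outcome.

Still open, as far as these compounds go, is whether a group of a different kind on this carbon, such as a saturated alkyl chain or a phenyl ring carrying a carboxylic acid or an amine, would shift the number beyond the scatter. Also open, from the compounds shown here alone, is whether a longer chain with more double bonds would read the same as 2-phenylethenyl.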